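The compounds below may be only part of what the source reports. "The series", "measured", "known", "first", "only" and "open" are said of these compounds alone.

Compound 1 `C=CC(=O)Nc1cccc(-c2nc3ccccc3s2)c1` gives in an ADME assay on HepG2 cells (Homo sapiens) for inhibition, with a stated time of 72 h (on this read-out lower numbers stand for an effect already at smaller amounts and higher numbers for an effect only at larger amounts of compound), only a limit, > 25000 nM.
Compound 2 `CC(C)(CCl)C(=O)Nc1cccc(-c2nc3ccccc3s2)c1` gives in this assay likewise only a limit, > 25000 nM.

Compound 2 thus stands at the edge of what this assay reports, and no number is known for it. The step from compound 1 to compound 2, a step that the two limits leave unreadable from compound 1 to compound 2, cannot be read because of the limit of > 25000 nM in this assay, at which 2 of the 2 values shown sit.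

Compound 3 `O=C(Nc1cccc(-c2nc3ccccc3s2)c1)c1ccncc1Cl` differs from compound 2 by 3-chloropyridin-4-yl in place of 1-(chloromethyl)-1-methylethyl on a carbonyl carbon. For the measured compounds named here, the only measured step is unreadable, so it offers no direction for this change; what the two measured values show is simply that both compounds sit at the limit. In this assay compound 3 is therefore expected to stay close to that limit, with the expected step being a step that the limit leaves unreadable from compound 2 to compound 3, and a limit rather than a number is the likeliest report. The estimate for compound 3 is 30000 nM, with a range from 8000 nM to 100000 nM.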

Compound 3, half-maximal effective concentration: > 25000 nM
Compound 3 was reported as a limit; the forecaster's own chance of this, stated with the estimate: 70%; the middle value is on the limit's open side.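

No new step can be read: compound 3 also gives only a limit, so its steps from compound 1 and from compound 2 stay unreadable because all three compounds sit at the same edge: the limit of > 25000 nM in this assay, at which 3 of the 3 values shown sit.

The compounds shown leave open whether the groups on the carbonyl carbon differ at all in this assay.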